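Widening the pyrazole substituent on the ether series

The source may report more compounds than this note shows. Statements on the series, on what has been measured and on what is new or still open speak of the compounds shown alone.

Of the compounds shown here, three that share one core have been measured in an assay on cells for displacement of a labelled ligand from Glucagon receptor (Homo sapiens), in the presence of a further agent that is not named here; a higher number here means a weaker inhibitor, a lower number a stronger inhibitor. Compound 1 `CCCC(Oc1ccc(-n2cc(F)cn2)cc1)c1ccc(C(=O)NCCC(=O)O)cc1` gives 1700 nM, the highest of the three numbers and so the weakest binder here. Compound 2 `CCCC(Nc1cnc(-n2cc(C(F)(F)F)cn2)nc1)c1ccc(C(=O)NCCC(=O)O)cc1` gives 100 nM, and compound 3 `CCCC(Nc1ccc(-n2cc(C(F)(F)F)cn2)nc1)c1ccc(C(=O)NCCC(=O)O)cc1` gives 170 nM. Both of these lie beyond the scatter from compound 1, but each differs from it in more than one place, so their values show only that tighter binding is reachable within this core.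

The unmeasured compound 4 `CCCC(Oc1ccc(-n2cc(C(F)(F)F)c(C)n2)cc1)c1ccc(C(=O)NCCC(=O)O)cc1` departs from compound 1 in a single place: 3-methyl-4-(trifluoromethyl)-1H-pyrazol-1-yl in place of 4-fluoro-1H-pyrazol-1-yl on an aromatic carbon. Within the data shown here, the trifluoromethyl-bearing pyrazoles of compound 2 and compound 3 sit with the two lower values, and on that ground an improvement is expected, though no single-change step supports it directly. The expected step in this assay from compound 1 to compound 4 is a decrease in the number, a 3.4-fold lower number from compound 1 to compound 4 (0.53 log units; beyond the scatter), beyond the scatter. Compound 4 is estimated at 500 nM, with a range from 150 nM to 1500 nM.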

Compound 4, inhibition constant: 1100 nM
Beside the measured number, compound 4's estimate is 2.2-fold (0.34 log units) below it; the measured number falls inside the stated range.
By their numbers in this assay, from the lowest: compounds 2 and 3 (each within the scatter of the next); then compounds 4 and 1 (each within the scatter of the next).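

In this assay, putting 3-methyl-4-(trifluoromethyl)-1H-pyrazol-1-yl in place of 4-fluoro-1H-pyrazol-1-yl gives a 1.5-fold lower number from compound 1 to compound 4 (0.19 log units; within the scatter), so this single change does not separate the two compounds. Among these compounds, this is the first direct reading at this position, on an aromatic carbon para to a large group, and it shows that the ether compounds keep a similar number with the larger group of 10 heavy atoms in place of the group of 6. Nothing measured here gives a reason for this result.

On these data alone, the change adds a methyl and swaps fluorine for trifluoromethyl together, so the share of each in the result stays unknown. Also open, as far as these compounds go, is how this ether compound would read with a nitrile or a chlorine in place of the fluorine on the pyrazole, or with the 3-methyl group alone.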